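Methoxy additions on the aromatic ring: cytotoxicity notes

This account rests on a few compounds, and the source may have more. Where it says the series, first, only, none or still open, it means among the compounds named here.

Measured in an ADME assay on K562 cells (Homo sapiens) for cytotoxicity, with a stated time of 72 h; a higher number here means a weaker inhibitor, a lower number a stronger inhibitor:
Compound 1 `COc1ccc(CNc2ncnc3c2ncn3C2CCCCO2)cc1` gives > 100000 nM, a limit.
Compound 2 `COc1ccc(CNc2ncnc3c2ncn3C2CCCCO2)c(OC)c1` gives > 25000 nM, a limit.
Compound 3 `COc1ccc(CNc2ncnc3c2ncn3C2CCCCO2)c(OC)c1OC` gives > 37500 nM, a limit.

Compound 2 stands at a limit in this assay, and the two other values shown are limits as well. The steps a step that the two limits leave unreadable from compound 1 to compound 2 and a step that the two limits leave unreadable from compound 2 to compound 3 are unreadable because of the limit of > 100000 nM in this assay, at which 1 of the 3 values shown sits, the limit of > 25000 nM in this assay, at which 1 of the 3 values shown sits, and the limit of > 37500 nM in this assay, at which 1 of the 3 values shown sits, give no number to compare.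

Compound 4 `COc1cc(OC)c(CNc2ncnc3c2ncn3C2CCCCO2)c(OC)c1` differs from compound 2 by methoxy in place of hydrogen on an aromatic carbon. The two measured methoxy steps bear on it, and both are of unreadable size, so no step beyond the scatter is expected in this assay, only another weak result.

Compound 4 is estimated at 50000 nM, range 20000 nM to 200000 nM, most likely reported as a limit again.

The expected step that the limit leaves unreadable from compound 2 to compound 4 is taken as within the scatter.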

Compound 4, half-maximal inhibitory concentration: > 50000 nM
Compound 4: no number, only a limit; the forecaster's own chance of this, stated with the estimate: 85%; the middle value lies on the limit itself.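

In this assay compound 4 gives > 50000 nM, a limit, and the step from compound 2 to compound 4 cannot be read. The compounds shown leave open how large any methoxy step is and what number compounds 1 to 4 would reach.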